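From compound 2 to compound 3: a longer chain

The compounds below may be only part of what the source reports. "The series", "measured", "known", "first", "only" and "open" are said of these compounds alone.

Measured in a functional assay on HeLa cells (Homo sapiens) for antiproliferative activity, read by MTT assay, with a stated time of 48 h (a lower number here means a stronger inhibitor, a higher number a weaker inhibitor), so far:
Compound 1 `COc1ccc(N(C)c2ccnc(Cl)n2)cc1` gives 917 nM
Compound 2 `COc1ccc(N(C)c2ccnc(Cl)n2)cc1OCC[Se]C#N` gives 436 nM

Of the two, compound 2 at 436 nM has the lower number. Going by the values given here, compound 3 `COc1ccc(N(C)c2ccnc(Cl)n2)cc1OCCC[Se]C#N` carries a group of 4 heavy atoms (2 carbon, 1 nitrogen, 1 selenium; no ring) in place of a group of 3 heavy atoms (1 carbon, 1 nitrogen, 1 selenium; no ring), on a saturated chain carbon, two bonds along the chain from an oxygen on an aromatic ring as its one change from compound 2. Among the compounds with values here, the only measured step is the modest 2.1-fold lower number from compound 1 to compound 2 (0.32 log units; beyond the scatter) and it bears on this change only indirectly. Within the data shown here, that step puts a group of 6 heavy atoms in place of a hydrogen atom, and no measured step varies the chain length. No step beyond the scatter is therefore expected in this assay here. The expected result is a 1.0-fold lower number from compound 2 to compound 3 (0.02 log units; within the scatter) and no more. The estimate for compound 3 is 420 nM as the expected value, with 190 nM to 900 nM as its range.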

Compound 3, half-maximal inhibitory concentration: 4710 nM
The estimate for compound 3 lay 11-fold (1.05 log units) below the measured number, and the stated range ends below it.
By their numbers in this assay, from the lowest: compound 2; then compound 1; then compound 3.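

In this assay, this position proved sensitive to chain length: the longer chain gave an 11-fold higher number from compound 2 to compound 3 (1.03 log units; beyond the scatter). Attaching a chain here therefore does not act in one direction, since the group on the longer chain gave a 5.1-fold higher number from compound 1 to compound 3 (0.71 log units; beyond the scatter), while the shorter one gave a 2.1-fold lower number from compound 1 to compound 2 (0.32 log units; beyond the scatter). Nothing measured here accounts for this reversal. The compounds shown leave open whether a still longer chain would continue the trend or reverse it, and how an amine or a carboxylic acid in place of the nitrile would read.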